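Three tolerated compounds and a fluorine shift

The source may report more compounds than this note shows. Statements on the series, on what has been measured and on what is new or still open speak of the compounds shown alone.

Compound 1 `O=c1cc(-c2ccccc2)oc2c(-c3cccc(F)c3)c(O)c(O)c(O)c12` gives > 100000 nM as a limit
Compound 2 `O=c1cc(-c2ccc(N3CCN(c4ccc(O)cc4)CC3)cc2)oc2cc(O)c(O)c(O)c12` gives > 100000 nM as a limit
Compound 3 `Oc1c(O)c(O)c2c(=S)cc(-c3ccccc3)oc2c1-c1cccc(F)c1` gives > 100000 nM as a limit

In a toxicity assay on Huh-7 cells (Homo sapiens) for cytotoxicity, read by CCK-8 assay, with a stated time of 24 h (a higher number here means that more compound is tolerated, a lower number that less compound is tolerated), compound 1 stands at > 100000 nM, which is a limit of the assay and not a number. Among the compounds with values here, it shares its place with compound 2 and compound 3 at the limit of > 100000 nM in this assay, at which 3 of the 3 values shown sit, so no measured compound here gives a number.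

Compound 4 `O=c1cc(-c2ccccc2)oc2c(-c3ccc(F)cc3)c(O)c(O)c(O)c12` has the same atoms as compound 1, joined differently, with 4-fluorophenyl in place of 3-fluorophenyl on an aromatic carbon . The group sits ortho to a fused ring and ortho to a hydroxy group.

Within the data shown here, no two measured compounds differ in one place, so the data offer no step to scale from. No change beyond the usual scatter is expected in this assay, and the assay will most likely again report only a limit. The expected step is a number no higher from compound 1 to compound 4 (the limit leaves the size open) as estimated here. For compound 4 the estimate is 100000 nM, with an expected range from 50000 nM to 200000 nM for any number obtained.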

Compound 4, half-maximal cytotoxic concentration: > 100000 nM
Compound 4 gave a limit, no number; the forecaster's own chance of this, stated with the estimate: 85%; the middle value sits exactly at the limit.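

In this assay compound 4 gives > 100000 nM, which is a limit and not a number. The step between compound 1 and compound 4 therefore cannot be read: the limit of > 100000 nM in this assay, at which 4 of the 4 values shown sit. The compounds shown leave open whether 4-fluorophenyl in place of 3-fluorophenyl changes tolerance at all, and at what concentration any of them would become cytotoxic.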